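The source may report more compounds than this note shows. Statements on the series, on what has been measured and on what is new or still open speak of the compounds shown alone.

Values in a functional assay for inhibition, with Homo sapiens as the target; on this read-out lower numbers stand for stronger inhibition and higher numbers for weaker inhibition:
- compound 1 `CCOC(=O)C(CCc1ccccc1)Nc1nc2ccccc2s1`: 520 nM
- compound 2 `COC(=O)[C@@H](CC1CCCCC1)Nc1nc2ccccc2o1`: 100 nM
- compound 3 `CC(C)c1ccc2oc(NC(CC3CCCCC3)c3ccccc3)nc2c1`: 6 nM

Compound 3 has the lowest number of the three, and its gaps to compound 2 and compound 1 both lie beyond the scatter. The next analogue, compound 4 `N#Cc1ccc2oc(NC(CC3CCCCC3)c3ccccc3)nc2c1`, has cyano in place of isopropyl on an aromatic carbon of the six-membered aromatic ring of carbon only (cyano in place of isopropyl on an aromatic carbon). The rest of the structure is unchanged.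

Within the data shown here, no pair of measured compounds differs in one place only, so the series gives no direct measure of a change at this carbon. In this assay a higher number is expected for compound 4, with a step beyond the scatter, though this is a weakly supported judgement. Among the measured compounds shown here, compound 3 starts from 6 nM, the lowest number so far, which leaves a rise as the likelier direction. The expected step is a 5.8-fold higher number from compound 3 to compound 4 (0.77 log units; beyond the scatter). For compound 4 the estimated value is 35 nM, with an expected range of 9 nM to 150 nM.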

Compound 4, half-maximal inhibitory concentration: 15 nM
The estimate for compound 4 lay 2.3-fold (0.37 log units) above the measured number; low and high end bracket the measured number.
By their numbers in this assay, from the lowest: compound 3; then compound 4; then compound 2; then compound 1.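

In this assay, among these compounds, the step (a 2.5-fold higher number from compound 3 to compound 4 (0.40 log units; beyond the scatter)) is the first direct reading at this aromatic carbon: activity here depends on the group it carries, though the size of the change is modest. The position accepts cyano, a group with a triple bond and a hydrogen-bond acceptor, in place of the purely carbon isopropyl, and compound 4 still gives 15 nM. Nothing measured on the two compounds bears on the reason for this step.

A single pair cannot show whether the trend extends to other groups on this carbon, such as an amine, a methoxy group or a carboxylic acid. Among the compounds shown here, also open is the effect of the ester in compound 1 and compound 2 relative to the phenyl in compound 3 and compound 4, which no one-place pair isolates.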